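Trimethoxyphenyl series against prostate cancer cells: pyrazoline variant

The compounds below may be only part of what the source reports. "The series", "measured", "known", "first", "only" and "open" are said of these compounds alone.

Measured:
compound 1, `COc1cc(C2=NN(C(C)=O)C(c3ccccc3C(F)(F)F)O2)cc(OC)c1OC` — 15.2%
compound 2, `COc1cc(C(=O)N/N=C/c2cccc(C(F)(F)F)c2)cc(OC)c1OC` — 79.8%
compound 3, `COc1cc(/C=N/NC(=O)c2cc(OC)c(OC)c(OC)c2)cc(OC)c1OC` — 48.3%

In a functional assay on PC-3 cells (Homo sapiens) for antiproliferative activity, read by MTT assay, tested at 5 uM (a lower number here means a weaker effect, a higher number a stronger effect of the compound at the concentration tested), compound 1 gives 15.2%, the lowest of the three numbers; compound 3 lies nearer to it and compound 2 furthest, both gaps beyond the scatter. Compound 4, `COc1cc(C2=NN(C(C)=O)C(c3ccc(Cl)c(Cl)c3)O2)cc(OC)c1OC`, keeps the core of compound 1 and alters one group: 3,4-dichlorophenyl in place of 2-(trifluoromethyl)phenyl on a saturated ring carbon. Among the compounds with values here, no measured pair shows this change, and compounds 2 and 3 do not share the core of compound 1, so they give no reference for the step. A small to moderate step is expected, more likely upward than downward, because compound 1 in this assay gives only 15.2%. For compound 4 the expected value is 25%, within 5% to 55%. This amounts to an expected step of a number 9.8 percentage points higher from compound 1 to compound 4 (within the scatter).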

Compound 4, a percentage reported as inhibition, at one concentration (the size of the read-out at that concentration, not a potency): 26.1%
Estimate against measurement, compound 4: 1.1 percentage points below; low and high end bracket the measured number.
By their numbers in this assay, from the lowest: compound 1; then compound 4; then compound 3; then compound 2.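

In this assay, within the data shown here, 3,4-dichlorophenyl in place of 2-(trifluoromethyl)phenyl on the saturated ring carbon gives the first reading at this position, with a modest step, a number 10.9 percentage points higher from compound 1 to compound 4 (beyond the scatter), so the read-out does respond to the aryl group held there. Even so, compound 4 reaches only 26.1% at the concentration tested. No measurement available here accounts for the step. Still open, on these data alone, is whether the step follows the loss of trifluoromethyl or the gain of the two chlorines, and whether an amine or a carboxylic acid on this phenyl group would move the number further.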